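Furan-2-yl to thiophen-2-yl on a shared core

The source may hold more compounds than are shown below. What is called first, only, known or untested is meant among the compounds shown, and "the series" means these compounds.

Compound 1 `COc1cc(-c2cccc3nc(-c4ccc(N)cc4)oc23)cc(OC)c1OC` gives 310 nM
Compound 2 `COc1cc(-c2cccc3nc(-c4ccco4)oc23)cc(OC)c1OC` gives 2600 nM

In a functional assay on NCI-H460 cells (Homo sapiens) for antiproliferative activity, read by MTT assay, with a stated time of 48 h (on this read-out higher numbers stand for weaker inhibition and lower numbers for stronger inhibition), compound 2 holds the higher of the two numbers, the weaker inhibition of the pair. Compound 3 `COc1cc(-c2cccc3nc(-c4cccs4)oc23)cc(OC)c1OC` has thiophen-2-yl in place of furan-2-yl on an aromatic carbon, each group a five-membered aromatic ring with 1 hetero atom. Going by the values given here, the one measured step (an 8.4-fold higher number from compound 1 to compound 2 (0.92 log units; beyond the scatter)) exchanged 4-aminophenyl for furan-2-yl, a much larger change of group, so no step beyond the scatter is expected here in this assay for this closer exchange. The expected step is a 1.2-fold lower number from compound 2 to compound 3 (0.07 log units; within the scatter) and stays small. Compound 3 is thus estimated at 2200 nM (range 900 nM to 5500 nM).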

Compound 3, half-maximal inhibitory concentration: 1600 nM
Estimate against measurement, compound 3: 1.4-fold (0.14 log units) above; the measured number falls inside the stated range.
By their numbers in this assay, from the lowest: compound 1; then compounds 3 and 2 (each within the scatter of the next).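

In this assay, thiophen-2-yl and furan-2-yl cannot be told apart at this position (a 1.6-fold lower number from compound 2 to compound 3 (0.21 log units; within the scatter)). The second five-membered ring also falls short of 4-aminophenyl (a 5.2-fold higher number from compound 1 to compound 3 (0.71 log units; beyond the scatter)), so the loss seen with compound 2 is not confined to furan-2-yl. No evidence is available to explain these results.

On these data alone, whether compound 1 owes its lower number to the amine or to the phenyl ring remains open. A plain phenyl, or a thiophen-2-yl carrying an amine, on this carbon would separate the two.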